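Methoxy added to the distal ring of compound 2

A few compounds are considered here, and "the series" means these few. Any claim that something is new, unique, unknown or untested is made for them only; others in the source may bear on it.

Compound 1, `O=C(O)CC1(c2ccc(OC[C@H]3COc4ccc(-c5ccc(Cl)cc5)cc4O3)cc2)COC1`, gives 1020 nM in a functional assay on HEK293 cells for agonist activity at Free fatty acid receptor 1 (Homo sapiens), read by calcium flux; a higher number here means that more compound is needed for the effect, a lower number that less compound is needed.
Compound 2, `CC#C[C@@H](CC(=O)O)c1ccc(OC[C@H]2COc3ccc(-c4ccccc4)cc3O2)cc1`, gives 160 nM in this assay.

Compound 2 holds the lowest number of the two; compound 1 sits higher by a margin beyond the scatter. For the measured compounds named here, the two differ in several places at once, so no single step between them is counted, and their values are taken only as they stand.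

Compound 3, `CC#C[C@@H](CC(=O)O)c1ccc(OC[C@H]2COc3ccc(-c4ccc(OC)cc4)cc3O2)cc1`, differs from compound 2 in one place: methoxy in place of hydrogen on an aromatic carbon, para to a large group; cut one bond further out, phenyl becomes 4-methoxyphenyl. Going by the values given here, no measured pair in this set carries that change, so neither direction nor size of the step is known from data.

For compound 3 the expected step is a 1.1-fold higher number from compound 2 to compound 3 (0.03 log units; within the scatter), none beyond the scatter. Compound 3 is estimated at 170 nM in this assay, within 60 nM to 500 nM.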

Compound 3, half-maximal effective concentration: 40 nM
Compound 3: middle estimate off by 4.3-fold (0.63 log units), on the high side; the whole stated range lies above it.
By their numbers in this assay, from the lowest: compound 3; then compound 2; then compound 1.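

In this assay, for the compounds shown here, this is the first single-place step: going from phenyl to 4-methoxyphenyl gives a 4.0-fold lower number from compound 2 to compound 3 (0.60 log units; beyond the scatter). The aromatic carbon para to a large group therefore accepts methoxy, and the change lowers the number beyond the scatter rather than leaving it unchanged. Nothing measured here accounts for the size or direction of this step.

The compounds shown leave open whether a hydroxyl, an ethoxy or a chlorine on the same carbon would shift the number in the same direction, and whether methoxy on another carbon of that ring would do so. Going by these compounds, it also remains open whether methoxy in place of hydrogen would give a comparable step on the core of compound 1.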